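Fluoro for methyl on the phenyl of a triazole sulfonamide

This account rests on a few compounds, and the source may have more. Where it says the series, first, only, none or still open, it means among the compounds named here.

Compound 1, `O=c1[nH]cc(S(=O)(=O)Nc2ccc(-c3cn(-c4ccccc4)nn3)cc2)c(=O)[nH]1`, gives 18000 nM in a functional assay on HepG2 cells (Homo sapiens) for antiproliferative activity, read by MTT assay, with a stated time of 24 h; a higher number here means a weaker inhibitor, a lower number a stronger inhibitor.
Compound 2, `Cc1ccc(-n2cc(-c3ccc(NS(=O)(=O)c4c[nH]c(=O)[nH]c4=O)cc3)nn2)cc1`, gives 11600 nM in this assay.

Among the compounds with values here, compound 2 has the lowest of the two numbers so far, but its only neighbour is compound 1, and the step of a 1.6-fold lower number from compound 1 to compound 2 (0.19 log units; within the scatter) is within the scatter, so the two compounds cannot be told apart on these data. Within the data shown here, that step, a methyl in place of hydrogen on an aromatic carbon, is the only measured step, and it shows that adding a small group at this position does not move the number beyond the scatter.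

Compound 3, `O=c1[nH]cc(S(=O)(=O)Nc2ccc(-c3cn(-c4ccc(F)cc4)nn3)cc2)c(=O)[nH]1`, differs from compound 2 by fluoro in place of methyl on an aromatic carbon. Among the measured compounds shown here, no measured step exchanges one small group for another at this position, so the expectation rests only on the one step seen, which was within the scatter. A change beyond the scatter is therefore not expected in this assay, in either direction, and the step of a 1.1-fold higher number from compound 2 to compound 3 (0.05 log units; within the scatter) is the estimate. Compound 3 is expected to give about 13000 nM, within a range from 6000 nM to 30000 nM.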

Compound 3, half-maximal inhibitory concentration: > 20000 nM
Compound 3 was reported as a limit (the forecaster's own chance of this, stated with the estimate: 10%); at least 1.5-fold (0.18 log units) between middle value and limit.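

The value for compound 3 in this assay is a limit of the assay and not a number: the limit of > 20000 nM in this assay, at which 1 of the 3 values shown sits. That limit means that only a floor can be read for each swap on this ring, both for fluoro in place of methyl (an at least 1.7-fold higher number from compound 2 to compound 3 (0.23 log units; that floor lies within the scatter)) and for fluoro in place of hydrogen (an at least 1.1-fold higher number from compound 1 to compound 3 (0.04 log units; that floor lies within the scatter)). The new information is that fluoro at this position gives a number no lower than methyl or hydrogen does, but with both floors inside the scatter, compound 3 could lie close to the other two compounds or far beyond them.

The compounds shown carry only hydrogen, methyl or fluoro at this position, so it remains open whether an amine, a carboxylic acid or a longer chain there would move the number beyond the scatter in either direction. They also leave open whether a change elsewhere on the shared core would matter more than any change at this position.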